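The source may hold more compounds than are shown below. What is called first, only, known or untested is meant among the compounds shown, and "the series" means these compounds.

In a functional assay on MDA-MB-231 cells (Homo sapiens) for antiproliferative activity, read by MTT assay, with a stated time of 72 h (a higher number here means a weaker inhibitor, a lower number a stronger inhibitor), compound 1 `COc1cc(-c2nccn2C)cc(OC)c1OC` gives > 100000 nM, which is a limit of the assay and not a number. Compound 2 `CCn1ccnc1-c1cc(OC)c(OC)c(OC)c1` gives > 100000 nM, which is also a limit. The evidence so far is thin: the limit of > 100000 nM in this assay, at which 2 of the 2 values shown sit. Compound 3 `CCCn1ccnc1-c1cc(OC)c(OC)c(OC)c1` differs from compound 2 by methyl in place of hydrogen on a saturated chain carbon, two bonds along the chain from an aromatic nitrogen, so ethyl becomes propyl. For the measured compounds named here, the only measured step, a step that the two limits leave unreadable from compound 1 to compound 2, offers no size to carry over, so no change beyond the usual scatter is expected in this assay. The estimated step is a number no higher from compound 2 to compound 3 (the limit leaves the size open). For compound 3 the expected value is 100000 nM, with an estimated range from 40000 nM to 250000 nM.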

Compound 3, half-maximal inhibitory concentration: > 100000 nM
Compound 3 ended at the assay's limit; the forecaster's own chance of this, stated with the estimate: 85%; the middle value sits exactly at the limit.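

For the compounds shown here, compound 1, compound 2 and compound 3 each give only a limit, not a number, so no step among them can be read. On these data alone, whether any change to the chain or the shared core would give a readable value stays open.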